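Series notes: compound 3 to compound 4

The source may hold more compounds than are shown below. What is called first, only, known or untested is meant among the compounds shown, and "the series" means these compounds.

Among the measured compounds shown here, compound 3 `c1ccc(-c2ccns2)c(OCC2=NCCN2)c1` is the only member of the series with a number in a functional assay for activation of Alpha-1B adrenergic receptor (Homo sapiens), read by calcium flux; a lower number here means that less compound is needed, a higher number that more compound is needed for the effect; there compound 3 gives 12.6 nM. For compound 1 `c1cnc(-c2ccccc2OCC2=NCCN2)nc1` the value < 100000 nM in this assay is a limit, not a number. For compound 2 `c1ccc(-c2ccncn2)c(OCC2=NCCN2)c1` the value < 100000 nM in this assay is likewise a limit. The steps a step that the two limits leave unreadable from compound 1 to compound 2, a step that the limit leaves unreadable from compound 1 to compound 3 and a step that the limit leaves unreadable from compound 2 to compound 3 therefore cannot be sized, as the limit of < 100000 nM in this assay, at which 2 of the 3 values shown sit, shows. Compound 4 `Cc1ccoc1-c1ccccc1OCC1=NCCN1` differs from compound 3 by 3-methylfuran-2-yl in place of 1,2-thiazol-5-yl on an aromatic carbon. For the measured compounds named here, no measured step bears directly on this change. Compound 4 is expected to stay in the region of compound 3, with a step of a 4.0-fold higher number from compound 3 to compound 4 (0.60 log units; beyond the scatter) that is uncertain in direction. The estimate for compound 4 in this assay is 50 nM, within 8 nM to 400 nM.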

Compound 4, half-maximal effective concentration: < 100000 nM
Compound 4: a limit, no number; the forecaster's own chance of this, stated with the estimate: 10%; the middle value is on the limit's open side.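

Compound 4 gives only a limit in this assay, so no new step from compound 1, compound 2 or compound 3 to compound 4 can be read: the limit of < 100000 nM in this assay, at which 3 of the 4 values shown sit.

The compounds shown leave open how far compound 1, compound 2 and compound 4 each lie from compound 3.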